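Swapping a basic piperazine for a sulfonylated one: expected cytotoxicity

A few compounds are considered here, and "the series" means these few. Any claim that something is new, unique, unknown or untested is made for them only; others in the source may bear on it.

Measured compounds:
- compound 1 `Cc1cc(/C=C/C#N)cc(C)c1Oc1nc(Nc2ccc(CN3CCNCC3)cc2)nc2ccsc12`: 3970 nM
- compound 2 `Cc1cc(/C=C/C#N)cc(C)c1Oc1nc(Nc2ccc(CN3CCN(S(C)(=O)=O)CC3)cc2)nc2sccc12`: 131000 nM
- compound 3 `Cc1cc(/C=C/C#N)cc(C)c1Oc1nc(Nc2ccc(N3CCCC(NS(C)(=O)=O)C3)cc2)nc2sccc12`: 112000 nM

In an ADME assay on MT4 cells (Homo sapiens) for cytotoxicity, read by MTT assay, with a stated time of 5 days (on this read-out lower numbers stand for higher toxicity in this test and higher numbers for lower toxicity in this test), compound 1 gives 3970 nM, the lowest number of the three, so it is the most toxic of this set; compound 3 sits well above it and compound 2 higher still, both gaps beyond the scatter. Compounds 2 and 3 each carry a methylsulfonyl group on their ring amine, and their two numbers lie close together: a 1.2-fold lower number from compound 2 to compound 3 (0.07 log units; within the scatter).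

Compound 4 `Cc1cc(/C=C/C#N)cc(C)c1Oc1nc(Nc2ccc(N3CCN(S(C)(=O)=O)CC3)cc2)nc2ccsc12` is not yet measured. It differs from compound 1 in one place: 4-(methylsulfonyl)piperazin-1-yl in place of (piperazin-1-yl)methyl on an aromatic carbon. The change therefore removes the free amine and brings in the methylsulfonyl group that compounds 2 and 3 share. Among the compounds with values here, no measured step covers this exact exchange. Still, compound 1 with its free piperazine shows a far lower number than compound 2 with its sulfonylated piperazine, and the step from compound 2 to compound 3 shows that moving the sulfonylated ring directly onto the aromatic carbon changes little. A large rise in the number is therefore expected for compound 4, that is, markedly lower toxicity in this assay, roughly a 20-fold higher number from compound 1 to compound 4 (1.30 log units; beyond the scatter). Compound 4 is estimated at 80000 nM, within a range of 25000 nM to 250000 nM.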

Compound 4, half-maximal cytotoxic concentration: 11500 nM
Beside the measured number, compound 4's estimate is 7.0-fold (0.84 log units) above it; measured number outside the range, below it.
By their numbers in this assay, from the lowest: compound 1; then compound 4; then compounds 3 and 2 (each within the scatter of the next).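

In this assay, the exchange on this aromatic carbon, para to a large group, gives a 2.9-fold higher number from compound 1 to compound 4 (0.46 log units; beyond the scatter), so replacing (piperazin-1-yl)methyl with 4-(methylsulfonyl)piperazin-1-yl lowers toxicity in this test, but only modestly. Within the data shown here, this is the first step here that keeps the core of compound 1 unchanged, whereas compounds 2 and 3 differ from compound 4 in their core as well as in this side group, so their much higher numbers cannot be read as the effect of the methylsulfonyl group alone. Nothing in the data explains the size of this step.

The exchange changes two things at once, removing the carbon link to the aromatic ring and adding the methylsulfonyl group, and the compounds shown do not tell which of the two accounts for the step. A plain piperazin-1-yl attached directly to the aromatic carbon on the core of compound 1 would separate the two changes, and an acetyl group in place of methylsulfonyl would show whether the sulfonyl group itself matters.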